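A few compounds are considered here, and "the series" means these few. Any claim that something is new, unique, unknown or untested is made for them only; others in the source may bear on it.

Working notes on the dichlorothienopyrimidine-free description: the shared core carries a urea-linked aryl and a basic amine chain. Compound 1 `CN(C)CCCNc1nc(-c2ccc(NC(=O)Nc3ccc(F)cc3)cc2)nc2c(Cl)c(Cl)sc12` gives 430 nM in a functional assay on HT-29 cells (Homo sapiens) for cytotoxicity, read by MTT assay, with a stated time of 72 h; a lower number here means a stronger inhibitor, a higher number a weaker inhibitor. Compound 2 `CN(C)CCCNc1nc(-c2ccc(NC(=O)Nc3ccc(Cl)cc3Cl)cc2)nc2c(Cl)c(Cl)sc12` gives 1320 nM, and compound 3 `Cc1ccc(NC(=O)Nc2ccc(-c3nc(NCCCN(C)C)c4sc(Cl)c(Cl)c4n3)cc2)cc1` gives 1320 nM. The two urea changes move in the same sense: a 3.1-fold higher number from compound 1 to compound 2 (0.49 log units; beyond the scatter) and a 3.1-fold higher number from compound 1 to compound 3 (0.49 log units; beyond the scatter), whereas no change at the digits printed from compound 2 to compound 3 (within the scatter). Compound 3 therefore sits level with compound 2, and both stand apart from compound 1 by the step above.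

Compound 4 `CCN(CC)CCCNc1nc(-c2ccc(NC(=O)Nc3ccc(C)cc3)cc2)nc2c(Cl)c(Cl)sc12` differs from compound 3 only in the amine end: diethylamino in place of dimethylamino on a saturated chain carbon, three bonds along the chain from a nitrogen on an aromatic ring. None of the three measured steps touches this end of the molecule; all three vary the aryl on the urea while the dimethylamino chain is kept. Among the compounds with values here, there is thus no measured precedent for the step to compound 4, and in the absence of one the working expectation is no change beyond the scatter, meaning a 1.0-fold lower number from compound 3 to compound 4 (0.01 log units; within the scatter) is expected to be small. For compound 4 the estimated value in this assay is 1300 nM, expected to fall between 450 nM and 3800 nM.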

Compound 4, half-maximal inhibitory concentration: 890 nM
The estimate for compound 4 lay 1.5-fold (0.16 log units) above the measured number; low and high end bracket the measured number.
By their numbers in this assay, from the lowest: compound 1; then compounds 4, 2 and 3 (each within the scatter of the next).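

Within the data shown here, at the amine end of the molecule, the one step available in this assay is a 1.5-fold lower number from compound 3 to compound 4 (0.17 log units; within the scatter). Among these compounds, this is the first reading at this position, and it shows that diethylamino can replace dimethylamino on the 3-(dimethylamino)propyl chain with no change beyond the scatter, at least with the 4-methylphenyl urea in place. No measured information accounts for this result or links it to any property of the two groups.

As far as these compounds go, it remains open whether the same exchange would stay within the scatter on the 4-fluorophenyl urea of compound 1. Also open, from the compounds shown here alone, is how this position responds to a ring amine such as pyrrolidine or morpholine, or to a longer chain carrying the amine.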